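From sec-butyl to allyl on an amine nitrogen

The source may report more compounds than this note shows. Statements on the series, on what has been measured and on what is new or still open speak of the compounds shown alone.

In a functional assay for inhibition, with Homo sapiens as the target (a higher number here means that more compound is needed for the effect, a lower number that less compound is needed), compound 1 (`CCCNCC(=O)Nc1ccc(C2=NNC(=O)CC2)cc1`) gives about 46.4 ug/mL as its reading. Compound 2 (`CCC(C)NCC(=O)Nc1ccc(C2=NNC(=O)CC2)cc1`) gives about 21.5 ug/mL as its reading, the lower of the two numbers, and compound 1 is its nearest neighbour. Within the data shown here, the only measured step shows a 2.2-fold lower number from compound 1 to compound 2 (0.33 log units; beyond the scatter) and is modest, though beyond the scatter. It came with methyl in place of hydrogen on a saturated chain carbon bound to an amine nitrogen and a saturated chain carbon.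

Compound 3 (`C=CCNCC(=O)Nc1ccc(C2=NNC(=O)CC2)cc1`) has yet to be measured. It carries allyl in place of sec-butyl on an amine nitrogen. Among the measured compounds shown here, with only that one step to go on, a move of similar modest size toward a higher number in this assay is expected, and the estimated step is a 1.8-fold higher number from compound 2 to compound 3 (0.25 log units; within the scatter) in this expectation. For compound 3 the estimate is 38 ug/mL with an expected range from 17 ug/mL to 85 ug/mL as its bounds.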

Compound 3, half-maximal effective concentration: about 21.5 ug/mL
Beside the measured number, compound 3's estimate is 1.8-fold (0.25 log units) above it; the measured number falls inside the stated range.
By their numbers in this assay, from the lowest: compounds 2 and 3 (each within the scatter of the next); then compound 1.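

In this assay, among these compounds, the amine nitrogen accepts allyl in place of sec-butyl with no change at the digits printed from compound 2 to compound 3 (within the scatter), so the branching methyl is not the only change at this position that goes with the lower reading. Starting from the unbranched chain, vinyl in place of ethyl comes with a 2.2-fold lower number from compound 1 to compound 3 (0.33 log units; beyond the scatter), a modest move of the same printed size as a 2.2-fold lower number from compound 1 to compound 2 (0.33 log units; beyond the scatter), so two different changes to the chain end in the same place. Nothing at hand says why these two groups read alike.

The compounds shown leave open whether a cyclopropyl or a propargyl group on this amine nitrogen would read like compound 2 and compound 3 or move further. They also leave open whether a longer chain, such as n-pentyl, would keep this reading.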